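A Pyridine Ring in Place of a Methylpyrrole

A few compounds are considered here, and "the series" means these few. Any claim that something is new, unique, unknown or untested is made for them only; others in the source may bear on it.

Compound 1 `CCN(Cc1ccoc1)C(=O)COc1ccc(C)cc1` carries a furan-3-yl group on a saturated chain carbon bound to an amide-type nitrogen; in an assay on HEK293 cells for agonist activity at transient receptor potential cation channel subfamily M member 8 (Homo sapiens), read by fluorescence and calcium flux, with a stated time of 15 min (on this read-out lower numbers stand for an effect already at smaller amounts and higher numbers for an effect only at larger amounts of compound), compound 1 gives 136 nM. Compound 2 `CCN(Cc1cccn1C)C(=O)COc1ccc(C)cc1` differs only in that ring, and in this assay compound 2 gives 21300 nM, the highest of the two numbers measured. The step of a 160-fold higher number from compound 1 to compound 2 (2.19 log units; beyond the scatter) shows how much that one exchange matters. Compound 3 `CCN(Cc1ccccn1)C(=O)COc1ccc(C)cc1` keeps everything else and brings in a different six-membered ring: pyridin-2-yl in place of 1-methyl-1H-pyrrol-2-yl on a saturated chain carbon bound to an amide-type nitrogen. For the measured compounds named here, no measured step covers this exact exchange; the only step available, a 160-fold higher number from compound 1 to compound 2 (2.19 log units; beyond the scatter), shows that leaving the furan cost a great deal, so the methylpyrrole appears to be a weak choice that a different ring may partly undo. In this assay compound 3 is therefore expected to show a 14-fold lower number from compound 2 to compound 3 (1.15 log units; beyond the scatter). The estimated value for compound 3 is 1500 nM, with a range from 200 nM to 10000 nM.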

Compound 3, half-maximal effective concentration: 16000 nM
Compound 3: the middle estimate sits 11-fold (1.03 log units) below what was measured; measured number above the stated range.
By their numbers in this assay, from the lowest: compound 1; then compounds 3 and 2 (each within the scatter of the next).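

In this assay, pyridin-2-yl in place of 1-methyl-1H-pyrrol-2-yl on a saturated chain carbon bound to an amide-type nitrogen gives a 1.3-fold lower number from compound 2 to compound 3 (0.12 log units; within the scatter) and so leaves the two compounds within the usual scatter, although one ring is five-membered and the other six-membered. Against the furan-3-yl group, the same pyridin-2-yl group gives a 120-fold higher number from compound 1 to compound 3 (2.07 log units; beyond the scatter) and so a large step of the kind seen before. A single step could not show this: two different replacements of the furan-3-yl group now sit at one level, and among these three compounds only compound 1 stands apart.

Still open, going by these compounds, is whether a furan-2-yl or a thiophen-3-yl group at this place would stay close to compound 1 or join compounds 2 and 3. Nothing at hand explains why the furan-3-yl group stands apart.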